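The source may report more compounds than this note shows. Statements on the series, on what has been measured and on what is new or still open speak of the compounds shown alone.

Compound 1 `Cc1oc2c([C@H]3CCN(C)C[C@H]3O)c(O)cc(O)c2c(=O)c1C(O)c1c(F)cccc1Cl`: 0%
Compound 2 `CN1CC[C@H](c2c(O)cc(O)c3c(=O)cc(/C=C/c4ccccc4)oc23)[C@H](O)C1`: 10%

In a functional assay on PC-3 cells (Homo sapiens) for inhibition, read by MTT assay, with a stated time of 48 h, tested at 10 uM (a higher number here means more inhibition of growth at the concentration tested, a lower number less inhibition of growth), compound 2 gives 10%, a number that the usual scatter of repeated measurements cannot separate from compound 1 at 0%. Compound 3 `CN1CC[C@H](c2c(O)cc(O)c3c(=O)cc(/C=C/c4cccc(Cl)c4)oc23)[C@H](O)C1` keeps the structure of compound 2 except for one change: chloro in place of hydrogen on an aromatic carbon. This places chloro in place of hydrogen on an aromatic carbon, turning phenyl into 3-chlorophenyl. Within the data shown here, no measured pair shows this change, so the expectation is only a small upward move, within the scatter, a number 3 percentage points higher from compound 2 to compound 3 (within the scatter). For compound 3, the estimated value is 13%, with an expected range of 0% to 32%.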

Compound 3, percent growth inhibition at one concentration: 53%
Beside the measured number, compound 3's estimate is 40 percentage points below it; the whole stated range lies below it.
By their numbers in this assay, from the lowest: compounds 1 and 2 (each within the scatter of the next); then compound 3.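

In this assay, a number 43 percentage points higher from compound 2 to compound 3 (beyond the scatter) follows from a single chloro in place of hydrogen, turning phenyl into 3-chlorophenyl. This shows that the aromatic ring at the end of the 2-phenylethenyl group is not a silent place: a change of one heavy atom there can move growth inhibition well beyond the scatter. Nothing measured here explains why this step is so large.

The compounds shown leave open whether chloro is special, as they include no fluoro, methoxy or amine at this carbon. Also open, as far as these compounds go, is what chloro would do on another carbon of that ring.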